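A few compounds are considered here, and "the series" means these few. Any claim that something is new, unique, unknown or untested is made for them only; others in the source may bear on it.

The measured compounds:
Compound 1, `CC(=O)c1c(NNc2ccc(C)cc2)cc(C)oc1=O`; in a functional assay on the whole organism for inhibition, with Rattus norvegicus as the target, read by paw edema, with a stated time of 1 h, at a dose of 50 mg/kg (a higher number here means more inhibition at the dose given (going by the name of the read-out), a lower number less inhibition), compound 1 gives 60.1%.
Compound 2, `CC(=O)c1c(NNc2ccc(Cl)cc2)cc(C)oc1=O`; in this assay compound 2 gives 54.4%.
Compound 3, `Cc1ccc(-n2nc3cc(C)oc(=O)c3c2C)cc1`; in this assay compound 3 gives 63.3%.

Compound 1 and compound 2 differ in one place only: chloro in place of methyl on an aromatic carbon. This change made a step of a number 5.7 percentage points lower from compound 1 to compound 2 (within the scatter), so the two numbers are within the usual scatter of each other. Compound 3 has a different core from compound 1, and the difference between the two cores is not broken down here. Compound 4, `Cc1cc2nn(-c3ccc(Cl)cc3)c(C)c2c(=O)o1`, has not yet been measured. It comes from compound 3 by the same change, described in the same words for the place where it sits: chloro in place of methyl on an aromatic carbon. This change has been seen twice among the compounds shown, once measured and once not. In this assay the expected step is a number 5.3 percentage points lower from compound 3 to compound 4 (within the scatter), because the same change earlier made a number 5.7 percentage points lower from compound 1 to compound 2 (within the scatter). On that basis compound 4 is estimated at 58%, expected to lie between 46% and 70%.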

Compound 4, a percentage reported as inhibition, in the whole organism at one dose (the size of the read-out at that dose, not a potency): 58.2%
Compound 4: the middle estimate sits 0.2 percentage points below what was measured; the range from low to high includes it.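

In this assay, putting chloro in place of methyl on the aromatic carbon gave a number 5.1 percentage points lower from compound 3 to compound 4 (within the scatter). Set beside the earlier step, the change carried over from one core to the other with no detectable difference in size: the same change on two cores in this assay, a number 5.7 percentage points lower (within the scatter) from compound 1 to compound 2 and a number 5.1 percentage points lower (within the scatter) from compound 3 to compound 4, 0.6 percentage points apart, within the scatter of two such steps Both steps lie within the scatter, however, so these two pairs do not show that chloro and methyl truly differ in this read-out, and agreement between two small steps at a single dose says nothing about potency or about how the change would behave on any further core.

The compounds shown carry only methyl or chloro at this place on the ring, so it remains open whether a larger departure, such as an amine, a carboxylic acid or a longer chain, would give a step beyond the scatter. On these data alone, it also remains open whether the two cores would still match for such a group, or at other doses and times.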